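Cytotoxicity notes on the hydrazone series, compound 3 outlook

A few compounds are considered here, and "the series" means these few. Any claim that something is new, unique, unknown or untested is made for them only; others in the source may bear on it.

Compound 1 `CC(/C=N/Nc1ccc([N+](=O)[O-])cc1)=N\NC(=O)c1ccc(C(F)(F)F)cc1` and compound 2 `CC(/C=N/Nc1ccc([N+](=O)[O-])cc1)=N\NC(=O)c1cccc(C)c1` have been tested in an ADME assay on J774 cells (Mus musculus, strain BALB/c) for cytotoxicity, read by resazurin assay, with a stated time of 72 h; on this read-out lower numbers stand for higher toxicity in this test and higher numbers for lower toxicity in this test. In this assay compound 1 gives 78700 nM. For compound 2 this assay reports only a limit, > 100000 nM, and compound 2 therefore stands without a number, at the limit of > 100000 nM in this assay, at which 1 of the 2 values shown sits. Compound 3 `CC(/C=N/Nc1ccc([N+](=O)[O-])cc1)=N\NC(=O)c1ccc(N(C)C)cc1` is not yet measured and differs by 4-(dimethylamino)phenyl in place of 3-methylphenyl on a carbonyl carbon. Within the data shown here, no step between measured compounds is available, so the expected change is none beyond the usual scatter, namely an at least 1.1-fold lower number from compound 2 to compound 3 (0.04 log units; that floor lies within the scatter). Compound 3 is expected to give about 90000 nM in this assay, within 40000 nM to 200000 nM.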

Compound 3, half-maximal cytotoxic concentration: > 100000 nM
Compound 3: only a limit was reported; the forecaster's own chance of this, stated with the estimate: 55%; middle value at least 1.1-fold (0.04 log units) away from the limit.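

Compound 3, with 4-(dimethylamino)phenyl on the carbonyl carbon, reaches the same limit as compound 2 in this assay, so this change gives no readable cytotoxicity value: the limit of > 100000 nM in this assay, at which 2 of the 3 values shown sit. Because both ends are limits, the step between these two compounds cannot be read. Dimethylamino in place of trifluoromethyl on an aromatic carbon gives an at least 1.2-fold higher number from compound 1 to compound 3 (0.10 log units; that floor lies within the scatter), so no firm separation is established.

Still open, on these data alone, is how far compound 2 and compound 3 lie past their limits. Also open, as far as these compounds go, is whether a carboxylic acid or a primary amine on an aromatic carbon would give a readable number in this assay.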